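This account rests on a few compounds, and the source may have more. Where it says the series, first, only, none or still open, it means among the compounds named here.

Measured in an assay on isolated protein for binding affinity to leukotriene B4 receptor 1 (Homo sapiens), tested at 1 uM; a higher number here means more inhibition at the concentration tested (going by the name of the read-out), a lower number less inhibition:
compound 1 `CCc1cc(C(C)=O)c(O)cc1OCCCCCCC#N` gives 73%;
compound 2 `CCc1cc(C(C)=O)c(O)cc1OCCCCCC[S+](C)[O-]` gives 50%;
compound 3 `CCc1cc(C(C)=O)c(O)cc1OCCCCCCC(=O)N(C)C` gives 61%.

Compound 3 stands second highest of the three, with a number 12 percentage points lower from compound 1 to compound 3 (beyond the scatter) and a number 11 percentage points higher from compound 2 to compound 3 (beyond the scatter). Compound 4 `CCc1cc(C(C)=O)c(O)cc1OCCCCCCC(=O)Nc1nn[nH]n1` differs from compound 3 by (2H-tetrazol-5-yl)amino in place of dimethylamino on a carbonyl carbon. All measured steps vary the same chain end: a number 23 percentage points lower from compound 1 to compound 2 (beyond the scatter), a number 12 percentage points lower from compound 1 to compound 3 (beyond the scatter), a number 11 percentage points higher from compound 2 to compound 3 (beyond the scatter), each modest in size. None of them brings in a ring or hydrogen-bond donors at that end, so the direction for compound 4 cannot be read from them; a step of similar modest size in this assay is expected, with no change beyond the scatter as the central guess, a number 1 percentage points higher from compound 3 to compound 4 (within the scatter). Compound 4 is estimated at 62%, within 40% to 85%.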

Compound 4, a percentage reported as inhibition, at one concentration (the size of the read-out at that concentration, not a potency): 83%
The estimate for compound 4 lay 21 percentage points below the measured number; the measured number falls inside the stated range.
By their numbers in this assay, from the lowest: compound 2; then compound 3; then compounds 1 and 4 (each within the scatter of the next).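

In this assay the number is higher after the change to (2H-tetrazol-5-yl)amino on the carbonyl carbon (a number 22 percentage points higher from compound 3 to compound 4 (beyond the scatter)), which brings a five-membered aromatic ring with hydrogen-bond donors to this chain end. The same group widens the range seen at this end (a number 33 percentage points higher from compound 2 to compound 4 (beyond the scatter)), yet it is not separated from the nitrile (a number 10 percentage points higher from compound 1 to compound 4 (within the scatter)). No available evidence accounts for the gain. As far as these compounds go, whether the ring or the amide hydrogen carries the gain remains open, and methylamino on the same carbonyl carbon or a carboxylic acid at this chain end would bear on that.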